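Moving the pyridine nitrogen: what to expect for compound 4

The source may hold more compounds than are shown below. What is called first, only, known or untested is meant among the compounds shown, and "the series" means these compounds.

In an ADME assay on the whole organism (plasma) for pharmacokinetics, with Rattus norvegicus as the target, with a stated time of 6 h, at a dose of 10 mg/kg by the oral route (a lower number here means less compound in the circulation, a higher number more compound in the circulation at the dose given), compound 1 `Cc1nc(NCC2CC2)nc(N[C@@H]2C[C@H](CO)[C@@H](O)[C@H]2O)c1-c1nc2ccccc2s1` gives 1410 ng.h/mL, compound 2 `Cc1nc(NCC2CCC2)nc(N[C@@H]2C[C@H](CO)[C@@H](O)[C@H]2O)c1-c1nc2ccccc2s1` gives 228 ng.h/mL, and compound 3 `Cc1nc(NCc2cccnc2)nc(N[C@@H]2C[C@H](CO)[C@@H](O)[C@H]2O)c1-c1nc2ccccc2s1` gives 9.57 ng.h/mL, the lowest of the three numbers. The drops were a 150-fold lower number from compound 1 to compound 3 (2.17 log units; beyond the scatter) and a 24-fold lower number from compound 2 to compound 3 (1.38 log units; beyond the scatter), each following a change to a pyridin-3-yl group. Compound 4 `Cc1nc(NCc2ccncc2)nc(N[C@@H]2C[C@H](CO)[C@@H](O)[C@H]2O)c1-c1nc2ccccc2s1` differs from compound 3 only in pyridin-4-yl in place of pyridin-3-yl on a saturated chain carbon bound to a nitrogen on an aromatic ring. For the measured compounds named here, no measured step moves the nitrogen within a pyridine ring, so those two large steps show only that a pyridine at this place goes with a low number in this assay. For compound 4 the expected step is therefore small, a 1.3-fold higher number from compound 3 to compound 4 (0.10 log units; within the scatter), and is expected to stay within the usual scatter. Compound 4 is estimated at 12 ng.h/mL, with a range from 3 ng.h/mL to 45 ng.h/mL.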

Compound 4, area under the concentration-time curve: 47.9 ng.h/mL
For compound 4 the middle estimate is 4.0-fold (0.60 log units) below the measured one, and the stated range ends below it.
By their numbers in this assay, from the lowest: compound 3; then compound 4; then compound 2; then compound 1.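

Moving the nitrogen alone, with the same atoms in the group, gives a 5.0-fold higher number from compound 3 to compound 4 (0.70 log units; beyond the scatter) in this assay, so where the nitrogen sits in the pyridine ring matters at this position, not just whether a pyridine is there. Pyridin-4-yl still recovers only part of the loss, with a 4.8-fold lower number from compound 2 to compound 4 (0.68 log units; beyond the scatter) and a 29-fold lower number from compound 1 to compound 4 (1.47 log units; beyond the scatter) in the same assay. Nothing measured here gives a reason for these steps.

Still open, on these data alone, is whether pyridin-2-yl or a plain phenyl ring, on the same saturated chain carbon, would fall nearer the pyridines or the cyclopropyl compound.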